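A few compounds are considered here, and "the series" means these few. Any claim that something is new, unique, unknown or untested is made for them only; others in the source may bear on it.

In a physicochemical assay for solubility (on this read-out lower numbers stand for lower solubility and higher numbers for higher solubility), compound 1 `O=C(Nc1ccccc1Cl)c1cc(Cl)ccc1O` gives 5 ug/mL. Compound 2 `O=C(Nc1c(Cl)cc(F)cc1Cl)c1cc(Cl)ccc1O` gives > 49 ug/mL, which is a limit of the assay and not a number. Compound 2 therefore has no exact reading, and it stands at the limit of > 49 ug/mL in this assay, at which 1 of the 2 values shown sits. Going by these compounds, its two values place it higher than compound 1, although the true distance between them remains open.

Compound 3 `O=C(Nc1c(Cl)cccc1Cl)c1cc(Cl)ccc1O` keeps the core of compound 2 and changes it in one place: hydrogen in place of fluoro on an aromatic carbon. Hydrogen stands in place of fluoro on an aromatic carbon, meta to two chloro groups and para to a large group. Among the measured compounds shown here, no measured pair shows what this exchange does in this assay, so any forecast carries wide uncertainty. With so small a change, compound 3 is expected to remain nearer to compound 2 than to compound 1. The expected step of an at least 1.4-fold lower number from compound 2 to compound 3 (0.14 log units; that floor lies within the scatter) is modest and downward, and it may not go beyond the scatter. For compound 3 the estimated value is 35 ug/mL, with an expected range from 12 ug/mL to 70 ug/mL.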

Compound 3, solubility: 21 ug/mL
Estimate against measurement, compound 3: 1.7-fold (0.22 log units) above; measured number inside the range.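

Hydrogen in place of fluoro on an aromatic carbon, meta to two chloro groups and para to a large group, comes with an at least 2.3-fold lower number from compound 2 to compound 3 (0.36 log units; beyond the scatter), so this single exchange moves the read-out in this assay by more than the scatter. Chloro in place of hydrogen on an aromatic carbon comes with a 4.2-fold higher number from compound 1 to compound 3 (0.62 log units; beyond the scatter), which gives this series a second single exchange with a step beyond the scatter, and this one has an exact size. The step from compound 2 remains a floor and not a full measure, because compound 2 carries a limit of the assay and not a number: the limit of > 49 ug/mL in this assay, at which 1 of the 3 values shown sits.

Going by these compounds, how far the true distance between compound 2 and compound 3 extends stays open, as does whether chloro, a methoxy group or an amine on that same aromatic carbon would go with a higher or a lower number than fluoro or hydrogen. On these data alone, the hydroxyl group and the amide of the shared core stay the same in all three compounds, so what a change at either of them would do in this assay also remains open.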